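Two Furan Swaps on Related Nucleoside Cores

This account rests on a few compounds, and the source may have more. Where it says the series, first, only, none or still open, it means among the compounds named here.

Three nucleoside-like compounds share a sugar attached to a fused two-ring core and differ in the aromatic group hanging from that core. Compound 1 `Cc1ncnc2c1c(-c1cc3ccccc3o1)cn2[C@@H]1O[C@H](CO)[C@@H](O)[C@H]1O` carries a 1-benzofuran-2-yl group, compound 2 `Cc1ncnc2c1c(-c1ccoc1)cn2[C@@H]1O[C@H](CO)[C@@H](O)[C@H]1O` a furan-3-yl group, and compound 3 `Cc1nc(N)c2c(-c3ccoc3)cn([C@@H]3O[C@H](CO)[C@@H](O)[C@H]3O)c2n1` a furan-3-yl group on a core that additionally bears an amino group; the difference between the core of compound 2 and the core of compound 3 is not broken down here. In a functional assay on CEM-DNR-bulk cells (Homo sapiens), read by MTT assay, with a stated time of 72 h (a lower number here means a stronger inhibitor, a higher number a weaker inhibitor), compound 1 reaches only the limit > 20000 nM. Compound 2 likewise reaches only the limit > 20000 nM in this assay. Compound 3 also reaches only the limit > 20000 nM in this assay. The change from compound 2 to compound 1, (1-benzofuran-2-yl in place of furan-3-yl on an aromatic carbon), therefore gives a step that the two limits leave unreadable from compound 2 to compound 1, because of the limit of > 20000 nM in this assay, at which 3 of the 3 values shown sit. Compound 4 `Cc1nc(N)c2c(-c3cc4ccccc4o3)cn([C@@H]3O[C@H](CO)[C@@H](O)[C@H]3O)c2n1` applies the same change to compound 3: 1-benzofuran-2-yl in place of furan-3-yl on an aromatic carbon. The step from compound 3 to compound 4 is expected to be a step that the limit leaves unreadable from compound 3 to compound 4 in this assay, an expectation resting on compound 2 and compound 1 sitting at the limit of > 20000 nM in this assay, at which 3 of the 3 values shown sit. Compound 4 is thus expected to give roughly 30000 nM, within a range from 12000 nM to 100000 nM, most likely again reported only as a limit.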

Compound 4, half-maximal inhibitory concentration: 6310 nM
Estimate against measurement, compound 4: 4.8-fold (0.68 log units) above; the measured number lies below the stated range.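

In this assay, putting 1-benzofuran-2-yl in place of furan-3-yl on the core of compound 3 gives an at least 3.1-fold lower number from compound 3 to compound 4 (0.50 log units; beyond the scatter), so on this core the change lowers the number beyond the usual scatter. Going by these compounds, the same change on the core of compound 2 gives a step that cannot be read, because the values at both of its ends are limits rather than numbers: the limit of > 20000 nM in this assay, at which 3 of the 4 values shown sit. This leaves one readable step on one core, which shows neither that the change carries over between these two cores nor that it fails to, and the true size of the step remains unknown since compound 3 also has only a limit.

The compounds shown place only these two aromatic groups at this point on the cores, so how a simple phenyl or a thiophene group would fare there remains open. Also open, on these data alone, is whether an amine or a carboxylic acid added to the 1-benzofuran-2-yl group would raise or lower the number for compound 4.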